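The source may report more compounds than this note shows. Statements on the series, on what has been measured and on what is new or still open speak of the compounds shown alone.

Compound 1 `CCCN(C)c1nc(Cc2c(F)cccc2F)cc(=O)[nH]1` gives 85000 nM.
Compound 2 `CCN(C)c1nc(Cc2c(F)cccc2F)c(C)c(=O)[nH]1` gives > 85000 nM, a limit and not a number.
Compound 3 `Cc1c(Cc2c(F)cccc2F)nc(N(C)C(C)C)[nH]c1=O` gives 79000 nM.

All three were tested in an ADME assay on MT4 cells (Homo sapiens) for cytotoxicity, read by MTT assay, with a stated time of 4 days; on this read-out lower numbers stand for higher toxicity in this test and higher numbers for lower toxicity in this test. For the measured compounds named here, compound 1 at 85000 nM and compound 3 at 79000 nM are the only two true numbers in the set, and they lie within the scatter of each other. Compound 2 gives > 85000 nM, which is a limit of the assay. Compound 2 accounts for (the limit of > 85000 nM in this assay, at which 1 of the 3 values shown sits).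

Compound 4 `CCCN(C)c1nc(Cc2c(F)cccc2F)c(C)c(=O)[nH]1` has propyl in place of isopropyl on a nitrogen on an aromatic ring, and the rest of compound 3 stays as it is (propyl in place of isopropyl on a nitrogen on an aromatic ring). Going by the values given here, the one measured step that bears on this change alters the same chain on that nitrogen, and it is an at least 1.0-fold lower number from compound 2 to compound 3 (0.03 log units; that floor lies within the scatter). That step shows no size beyond the scatter, so no shift beyond the scatter is expected in this assay, in either direction. The expected step is a 1.0-fold higher number from compound 3 to compound 4 (0.01 log units; within the scatter). A reading reported only as a limit is also possible for compound 4. For compound 4 the estimated value is 80000 nM, with an expected range from 50000 nM to 125000 nM.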

Compound 4, half-maximal cytotoxic concentration: > 81000 nM
Compound 4: a limit, no number (the forecaster's own chance of this, stated with the estimate: 35%); at least 1.0-fold (0.00 log units) between middle value and limit.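

In this assay, the exchange of isopropyl for propyl on a nitrogen on an aromatic ring gives an at least 1.0-fold higher number from compound 3 to compound 4 (0.01 log units; that floor lies within the scatter), so this change of chain shape, with the same count of carbon atoms, has so far shown no shift beyond the scatter. For the compounds shown here, compound 4 gives > 81000 nM, which is a limit and not a number, and it is the second compound in the set reported in this form: the limit of > 81000 nM in this assay, at which 1 of the 4 values shown sits. The steps to compound 4 from compound 2 and from compound 1 cannot be read, so the result adds nothing on the methyl on the aromatic carbon, and the only readable information about this position remains the floor of the step from the branched chain to the straight one.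

From the compounds shown here alone, how far compound 4 truly stands from compound 3 stays open, and so does whether any step at this nitrogen would exceed the scatter. The compounds shown also leave open what a longer chain such as butyl, or a ring such as piperidine in place of the methyl(propyl)amino group, would give in this assay.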